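Notes on the Shared Core: Amide Replaced by Free Acid

A few compounds are considered here, and "the series" means these few. Any claim that something is new, unique, unknown or untested is made for them only; others in the source may bear on it.

Compound 3 `C=CC1=C(C(=O)NCc2ccccc2)C(c2ccc(Cl)c(Cl)c2)OC1` stands at the limit of a functional assay on SW480 cells (Homo sapiens) for cytotoxicity, read by MTT assay, with a stated time of 24 h; on this read-out lower numbers stand for stronger inhibition and higher numbers for weaker inhibition: in that read-out compound 3 gives > 100000 nM, which is a limit of the assay and not a number. For the measured compounds named here, compound 1 `C=CC1=C(C(=O)NCCCCC)C(c2ccc(Cl)c(Cl)c2)OC1` is the only member with a number; in this assay compound 1 gives 27500 nM. Compound 2 `C=CC1=C(C(=O)NCC(C)C)C(c2ccc(Cl)c(Cl)c2)OC1` likewise sits at the limit, since compound 2 gives > 100000 nM in this assay, again a limit rather than a number. Two of the three values thus rest at the limit of > 100000 nM in this assay, at which 2 of the 3 values shown sit.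

The step to compound 4 `C=CC1=C(C(=O)O)C(c2ccc(Cl)c(Cl)c2)OC1` is hydroxy in place of benzylamino on a carbonyl carbon. Going by the values given here, none of the measured steps touches the carbonyl carbon; all three vary the group on the saturated chain carbon bound to the amide-type nitrogen. Those steps show an at least 3.6-fold higher number from compound 1 to compound 2 (0.56 log units; beyond the scatter) and an at least 3.6-fold higher number from compound 1 to compound 3 (0.56 log units; beyond the scatter), while a step that the two limits leave unreadable from compound 2 to compound 3. Among the compounds with values here, the change from compound 3 to compound 4 removes the amide-type nitrogen altogether, so no measured step gives its size or direction; what is known is only that two of three members already sit at the limit of > 100000 nM in this assay, at which 2 of the 3 values shown sit. Compound 4 is expected to remain at or near that limit, with the estimated step of a number no higher from compound 3 to compound 4 (the limit leaves the size open). The estimate for compound 4 is 100000 nM, within 40000 nM to 300000 nM.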

Compound 4, half-maximal inhibitory concentration: > 100000 nM
Compound 4: no number, only a limit (the forecaster's own chance of this, stated with the estimate: 70%); the middle value sits exactly at the limit.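

Hydroxy in place of benzylamino is the first change at the carbonyl carbon itself rather than on the chain, and removing the amide-type nitrogen does not bring a number back in this assay: the limit of > 100000 nM in this assay, at which 3 of the 4 values shown sit.

For the compounds shown here, the one readable step is an at least 3.6-fold higher number from compound 1 to compound 4 (0.56 log units; beyond the scatter), where pentylamino on the carbonyl carbon gives way to hydroxy. Among the groups shown on that carbon, pentylamino therefore remains the only one that gives a number, while isobutylamino, benzylamino and hydroxy all end at a limit; the steps from compound 2 and from compound 3 to compound 4 cannot be read, as both ends of each are limits.

On these data alone, it remains open whether a longer straight chain on the carbonyl carbon, such as octylamino, would give a lower number than compound 1, and whether a methyl ester in place of the hydroxy would give any number at all. As far as these compounds go, the order among compound 2, compound 3 and compound 4 also stays open, since all three rest at a limit.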